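Amide-nitrogen aryl swap: compound 3 to compound 4

The source may report more compounds than this note shows. Statements on the series, on what has been measured and on what is new or still open speak of the compounds shown alone.

Measured in an assay on isolated protein for inhibition of histone deacetylase 4 (Homo sapiens), with a stated time of 1 h; a lower number here means a stronger inhibitor, a higher number a weaker inhibitor:
compound 1 `O=C(COc1ccc2cc(/C=C3/SC(=O)NC3=O)ccc2c1)Nc1ccc(Br)cc1F` gives 1900 nM
compound 2 `Cc1cc(Br)ccc1NC(=O)COc1ccc2cc(/C=C3/SC(=O)NC3=O)ccc2c1` gives 550 nM
compound 3 `Cc1ccc(NC(=O)COc2ccc3cc(/C=C4/SC(=O)NC4=O)ccc3c2)cc1Cl` gives 1100 nM

Compound 3 holds the second highest of the three numbers. The two measured steps that end at it are a 1.7-fold lower number from compound 1 to compound 3 (0.24 log units; within the scatter) and a 2.0-fold higher number from compound 2 to compound 3 (0.30 log units; within the scatter); both lie within the scatter, so no order among the three can be read from these values. Going by the values given here, the only step beyond the scatter is a 3.5-fold lower number from compound 1 to compound 2 (0.54 log units; beyond the scatter), which is methyl in place of fluoro on an aromatic carbon.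

Compound 4 `Cc1cc(NC(=O)COc2ccc3cc(/C=C4/SC(=O)NC4=O)ccc3c2)no1` has not yet been measured. Its difference from compound 3 is 5-methyl-1,2-oxazol-3-yl in place of 3-chloro-4-methylphenyl on an amide-type nitrogen. Among the compounds with values here, the two measured steps that touch the amide-type nitrogen each exchange one six-membered aromatic ring of carbon only for another and stay within the scatter; no measured step exchanges such a ring for a five-membered aromatic ring with two hetero atoms, so there is no direct precedent. Within the data shown here, with only that indirect guidance, the step to compound 4 is expected to be a 1.4-fold higher number from compound 3 to compound 4 (0.13 log units; within the scatter), with wide uncertainty. Compound 4 is estimated at 1500 nM, with a range from 500 nM to 5000 nM.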

Compound 4, half-maximal inhibitory concentration: 1700 nM
Compound 4: the middle estimate sits 1.1-fold (0.05 log units) below what was measured; measured number inside the range.
By their numbers in this assay, from the lowest: compounds 2, 3, 4 and 1 (each within the scatter of the next, the first and the last beyond it).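

On the amide-type nitrogen, the position also accepts a five-membered aromatic ring with 2 hetero atoms in this assay: 5-methyl-1,2-oxazol-3-yl in place of 3-chloro-4-methylphenyl gives a 1.5-fold higher number from compound 3 to compound 4 (0.19 log units; within the scatter), and in place of 4-bromo-2-fluorophenyl it gives a 1.1-fold lower number from compound 1 to compound 4 (0.05 log units; within the scatter), so across these pairs neither the six-membered ring of carbon only nor the halogen is shown to be required. The exception is 4-bromo-2-methylphenyl, where the same kind of exchange gives a 3.1-fold higher number from compound 2 to compound 4 (0.49 log units; beyond the scatter), which makes compound 2 the only one that stands clearly apart from the isoxazole compound and goes against any reading of this position as indifferent to the group it carries. No supporting measurement bears on the reason for these differences.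

Still open, on these data alone, is whether the methyl on the new ring matters, which the unsubstituted 1,2-oxazol-3-yl group would test, and whether a ring carrying a carboxylic acid or an amine would keep the number in this range. Also open is whether a saturated group such as cyclohexyl on the amide-type nitrogen would behave like the aromatic rings shown here.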